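Swapping a chlorophenyl for a fluorophenyl amide: expected tolerance

The compounds below may be only part of what the source reports. "The series", "measured", "known", "first", "only" and "open" are said of these compounds alone.

Of the compounds shown here, three that share one core have been tested in a toxicity assay on THP-1 cells (Homo sapiens) for inhibition; a lower number here means that less compound is tolerated, a higher number that more compound is tolerated. Compound 1 `COc1ccc(-c2cnc(NC(=O)c3ccn[nH]3)n2C)cc1` carries a 1H-pyrazol-5-yl group on the carbonyl carbon of its amide. Compound 2 `COc1ccc(-c2cnc(NC(=O)c3ccc(O)cc3)n2C)cc1` carries a 4-hydroxyphenyl there, and compound 3 `COc1ccc(-c2cnc(NC(=O)c3ccc(Cl)cc3)n2C)cc1` a 4-chlorophenyl. In this assay compound 1 gives only a limit of the assay, not a number, > 100000 nM. Compound 2 also gives a limit, > 100000 nM. Compound 3 likewise gives a limit, > 100000 nM. Because all three sit at the limit of > 100000 nM in this assay, at which 3 of the 3 values shown sit, the steps between them cannot be read: a step that the two limits leave unreadable from compound 1 to compound 2, a step that the two limits leave unreadable from compound 1 to compound 3 and a step that the two limits leave unreadable from compound 2 to compound 3 are all hidden by the limit. Compound 3 therefore stands at the limit of this assay, alongside the other two.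

Compound 4 `COc1ccc(-c2cnc(NC(=O)c3cccc(F)c3)n2C)cc1` has not yet been measured. It differs from compound 3 in one place: 3-fluorophenyl in place of 4-chlorophenyl on a carbonyl carbon. Of the measured steps, only those ending in compound 3 bear on this change, and each was unreadable. With every measured compound tolerated up to the limit, no step beyond the scatter is expected in this assay. The expected step is a number no higher from compound 3 to compound 4 (the limit leaves the size open). Compound 4 is therefore estimated at 100000 nM, in a range from 50000 nM to 300000 nM, most likely again reported only as a limit.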

Compound 4, half-maximal cytotoxic concentration: > 100000 nM
Compound 4 ended at the assay's limit; the forecaster's own chance of this, stated with the estimate: 85%; the middle value sits exactly at the limit.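

Compound 4 reads as a limit of this assay, not a number, as do compound 1, compound 2 and compound 3, so none of the steps among these four compounds can be read: the limit of > 100000 nM in this assay, at which 4 of the 4 values shown sit.

The compounds shown leave open where the true value of each lies, and whether the groups on the carbonyl carbon differ at all in this assay.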